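Difluoro for dimethoxy on the carbonyl aryl ring

This account rests on a few compounds, and the source may have more. Where it says the series, first, only, none or still open, it means among the compounds named here.

Two compounds of the series have numbers in a functional assay on MCF7 cells (Homo sapiens) for inhibition, read by sulforhodamine B assay, with a stated time of 48 h (a higher number here means a weaker inhibitor of growth, a lower number a stronger inhibitor of growth), so far. Compound 1 `COc1cc(-c2cc(/C=C/C(=O)c3ccc(Cl)c(Cl)c3)[nH]n2)cc(OC)c1OC` gives 1800 nM in this assay. Among the compounds with values here, compound 2 `COc1ccc(C(=O)/C=C/c2cc(-c3cc(OC)c(OC)c(OC)c3)n[nH]2)cc1OC` gives 820 nM in this assay, the lowest of the two numbers; the one step available, a 2.2-fold lower number from compound 1 to compound 2 (0.34 log units; beyond the scatter), separates them. Compound 3 `COc1cc(-c2cc(/C=C/C(=O)c3ccc(F)c(F)c3)[nH]n2)cc(OC)c1OC` has not yet been measured in this assay. It differs from compound 2 in one place: 3,4-difluorophenyl in place of 3,4-dimethoxyphenyl on a carbonyl carbon. Within the data shown here, the only measured step that bears on this change is a 2.2-fold lower number from compound 1 to compound 2 (0.34 log units; beyond the scatter), in which a dihalogenated phenyl was replaced by the dimethoxyphenyl; the new change runs the opposite way, from dimethoxyphenyl back to a dihalogenated phenyl. A modest rise in the number, of roughly that size, is therefore expected for compound 3, as a 1.8-fold higher number from compound 2 to compound 3 (0.26 log units; within the scatter). Compound 3 is accordingly estimated at 1500 nM in this assay, within a range of 600 nM to 4000 nM.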

Compound 3, concentration for 50% growth inhibition: 3200 nM
The estimate for compound 3 lay 2.1-fold (0.33 log units) below the measured number, and the stated range covers the measured number.
By their numbers in this assay, from the lowest: compound 2; then compounds 1 and 3 (each within the scatter of the next).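

In this assay, the 3,4-dimethoxyphenyl group on the carbonyl carbon now stands apart from a second dihalogenated ring as well, with a 3.9-fold higher number from compound 2 to compound 3 (0.59 log units; beyond the scatter) in the replacement by 3,4-difluorophenyl. The two halogenated rings are not separated, since a 1.8-fold higher number from compound 1 to compound 3 (0.25 log units; within the scatter) gives no order between 3,4-difluorophenyl and 3,4-dichlorophenyl at this position. Nothing at hand accounts for the difference between the dimethoxyphenyl compound and the dihalogenated pair.

Going by these compounds, it remains open whether the lower number of compound 2 follows from the two methoxy groups together or from one of them, which a 3-methoxyphenyl or 4-methoxyphenyl ring on the carbonyl carbon would test. Also open, on these data alone, is how a 3,4-dihydroxyphenyl or 4-aminophenyl ring would compare there.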